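The source may hold more compounds than are shown below. What is called first, only, known or untested is meant among the compounds shown, and "the series" means these compounds.

Working notes on the series. Of the compounds shown here, three sharing one core have been measured in a functional assay on the whole organism (strain albino) for inhibition, with Rattus norvegicus as the target, read by paw edema, with stated times of 1 h and 2 h, at a dose of 100 mg/kg by the oral route; on this read-out lower numbers stand for less inhibition and higher numbers for more inhibition at the one dose given (going by the name of the read-out). Compound 1 `N#Cc1c(-c2ccc(Cl)cc2)nc(SCC(=O)Nn2c(COc3ccc(Cl)cc3Cl)nc3ccccc3c2=O)[nH]c1=O` gives 64.9% in this assay. Compound 2 `N#Cc1c(-c2ccccc2)nc(SCC(=O)Nn2c(COc3ccc(Cl)cc3Cl)nc3ccccc3c2=O)n(Cc2ccccc2)c1=O`, which carries a benzyl group on the ring nitrogen and an unsubstituted phenyl, gives 79%. Compound 3 `Cn1c(SCC(=O)Nn2c(COc3ccc(Cl)cc3Cl)nc3ccccc3c2=O)nc(-c2ccc(Cl)cc2)c(C#N)c1=O` gives 73.7%. On these numbers compound 3 stands second of the three, with compound 2 nearest and compound 1 furthest, and both gaps lie within the scatter. Among the measured compounds shown here, the one single-point step measured so far, methyl in place of hydrogen on the aromatic nitrogen, moved the read-out by a number 8.8 percentage points higher from compound 1 to compound 3 (within the scatter), a change within the scatter.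

Compound 4 `N#Cc1c(-c2ccc(Cl)cc2)nc(SCC(=O)Nn2c(COc3ccc(Cl)cc3Cl)nc3ccccc3c2=O)n(Cc2ccccc2)c1=O` is not yet measured. It differs from compound 3 by phenyl in place of hydrogen on a saturated chain carbon bound to an aromatic nitrogen; cut one bond further out, the change reads methyl to benzyl. For the measured compounds named here, no measured step bears directly on this change. Going by the values given here, the only guide is compound 2, which already carries the benzyl group on the ring nitrogen and, at 79%, sits within the scatter of compound 3. The step from compound 3 to compound 4 is therefore expected to be small, a number 3.3 percentage points higher from compound 3 to compound 4 (within the scatter), with no direction that clears the scatter. The estimate for compound 4 in this assay is 77%, within a range from 67% to 87%.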

Compound 4, a percentage reported as inhibition, in the whole organism at one dose (the size of the read-out at that dose, not a potency): 77.2%
For compound 4 the middle estimate is 0.2 percentage points below the measured one; the range from low to high includes it.
By their numbers in this assay, from the lowest: compounds 1, 3, 4 and 2 (each within the scatter of the next, the first and the last beyond it).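

Among the compounds shown here, on the aromatic nitrogen, benzyl in place of hydrogen gives the first step in this assay that clears the scatter, a number 12.3 percentage points higher from compound 1 to compound 4 (beyond the scatter), while methyl in place of hydrogen stays inside it, a number 8.8 percentage points higher from compound 1 to compound 3 (within the scatter). The direct change of phenyl in place of hydrogen on the saturated chain carbon bound to that nitrogen does not separate the two substituted compounds, a number 3.5 percentage points higher from compound 3 to compound 4 (within the scatter), so the data support a difference from the unsubstituted nitrogen for benzyl but give no order between benzyl and methyl. With benzyl on the nitrogen, chloro in place of hydrogen on the aromatic carbon also leaves the read-out within the scatter, a number 1.8 percentage points lower from compound 2 to compound 4 (within the scatter), so this pair shows no effect of that chloro in this assay.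

No evidence beyond these read-outs bears on what lies behind the steps. As far as these compounds go, it remains open how a longer chain, or a chain ending in an amine or a carboxylic acid, would read on the aromatic nitrogen, and how a methoxy group would read in place of the chloro, while a single dose leaves the dose dependence of every step unknown.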